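Methyl to amino on a sulfonyl sulfur: tolerability notes

A few compounds are considered here, and "the series" means these few. Any claim that something is new, unique, unknown or untested is made for them only; others in the source may bear on it.

Measured so far:
compound 1 `Cc1cc(C)cc(S(=O)(=O)n2c(SCC(=O)Nc3ccccc3S(C)(=O)=O)nc3ccccc32)c1`: 9310 nM
compound 2 `Cc1cc(C)cc(S(=O)(=O)n2c(SCC(=O)Nc3ccccc3S(N)(=O)=O)nc3ccccc32)c1`: 25000 nM
compound 3 `Cc1cc(C)cc(S(=O)(=O)n2c(OCC(=O)Nc3ccc(S(C)(=O)=O)cc3Cl)nc3ccccc32)c1`: > 228000 nM (a limit of the assay)

In an ADME assay on MT4 cells (Homo sapiens) for cytotoxicity, read by MTT assay, with a stated time of 5 days (a higher number here means that more compound is tolerated, a lower number that less compound is tolerated), compound 1 gives 9310 nM and compound 2 gives 25000 nM. The two are separated by one change, (amino in place of methyl on a sulfonyl sulfur), and that change made a 2.7-fold higher number from compound 1 to compound 2 (0.43 log units; beyond the scatter). For compound 3 the value > 228000 nM in this assay is a limit, not a number; (the limit of > 228000 nM in this assay, at which 1 of the 3 values shown sits). The core of compound 3 differs from the core of compound 1 in more than one place, and the difference between the two cores is not broken down here.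

Compound 4, `Cc1cc(C)cc(S(=O)(=O)n2c(OCC(=O)Nc3ccc(S(N)(=O)=O)cc3Cl)nc3ccccc32)c1`, is not yet measured in this assay. It differs from compound 3 by amino in place of methyl on a sulfonyl sulfur, the same change as between compound 1 and compound 2, at the same kind of place; cut one bond further out it reads 2-chloro-4-(methylsulfonyl)phenyl to 2-chloro-4-sulfamoylphenyl here, against 2-(methylsulfonyl)phenyl to 2-sulfamoylphenyl there.

Because compound 3 already stands at the limit > 228000 nM, compound 4 is expected to sit at that limit or beyond it. The earlier pair moved toward a higher number, a 2.7-fold higher number from compound 1 to compound 2 (0.43 log units; beyond the scatter), and the same direction is expected here. For compound 4 the estimate in this assay is 350000 nM, within 180000 nM to 900000 nM, and the assay is expected most likely to report only a limit again. The step this estimate means from compound 3 to compound 4 is a step that the limit leaves unreadable from compound 3 to compound 4.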

Compound 4, half-maximal cytotoxic concentration: > 227000 nM
Compound 4 gave a limit, no number; the forecaster's own chance of this, stated with the estimate: 85%; the middle value does not contradict the limit.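

Among the compounds shown here, compound 3 and compound 4 each give only a limit of the assay in this assay, not a number, and no step between them can be read. The compounds shown leave open whether amino in place of methyl on a sulfonyl sulfur, which gave a 2.7-fold higher number from compound 1 to compound 2 (0.43 log units; beyond the scatter), changes tolerability at all in the series of compound 3 and compound 4.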